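The compounds below may be only part of what the source reports. "The series", "measured", "known", "first", "only" and "open" are said of these compounds alone.

In a functional assay on HCT-116 cells (Homo sapiens) for cytotoxicity, read by scintillation counting and thymidine incorporation, with a stated time of 72 h (a higher number here means a weaker inhibitor, a lower number a stronger inhibitor), compound 1 (`COc1cc(OC)cc(C(=CC(N)=O)c2ccc(OC)c(OC)c2)c1`) gives > 10000 nM, which is a limit and not a number. Compound 3 (`C=C(c1cc(OC)cc(OC)c1)c1ccc(OC)c(OC)c1`) gives > 10000 nM, again a limit. Compound 2 (`COc1cc(OC)cc(C(=Cc2ccccc2)c2ccc(OC)c(O)c2)c1`) gives > 10000 nM, also a limit, so its starting point has no exact value. All the measured compounds therefore stand at the limit of > 10000 nM in this assay, at which 3 of the 3 values shown sit. Compound 4 (`COc1cc(OC)cc(C(=CC#N)c2ccc(OC)c(O)c2)c1`) differs from compound 2 by cyano in place of phenyl on a double-bonded chain carbon bound to a double-bonded chain carbon. Within the data shown here, the only measured step changing a group at this place is a step that the two limits leave unreadable from compound 1 to compound 3, and it offers no size to carry over. Only a small move towards stronger inhibition is therefore expected, an at least 1.6-fold lower number from compound 2 to compound 4 (0.22 log units; that floor lies within the scatter), and the assay may well report a limit again. For compound 4 the estimated value is 6000 nM, with an expected range of 800 nM to 15000 nM.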

Compound 4, half-maximal inhibitory concentration: 2.5 nM
Beside the measured number, compound 4's estimate is 2400-fold (3.38 log units) above it, and the stated range ends above it.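

In this assay, the group on a double-bonded chain carbon bound to a double-bonded chain carbon proves able to carry a very large change: cyano in place of phenyl gives an at least 4000-fold lower number from compound 2 to compound 4 (3.60 log units; beyond the scatter). The earlier step at this place could not be read, so this is the first size shown there. Compound 4 is also the only compound shown that gives an exact value rather than a limit: the limit of > 10000 nM in this assay, at which 3 of the 4 values shown sit. 

The compounds shown leave open whether a carboxylic acid, an amine or a longer chain ending in a nitrile would hold such a value at this place. They also leave open whether cyano would have the same effect on a different core.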